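A few compounds are considered here, and "the series" means these few. Any claim that something is new, unique, unknown or untested is made for them only; others in the source may bear on it.

Measured compounds in an assay for inhibition of Maternal embryonic leucine zipper kinase (Homo sapiens), read by ADP-Glo, with a stated time of 0.5 h; a higher number here means a weaker inhibitor, a lower number a stronger inhibitor:
compound 1 `CC(=O)c1sc(NC(C)C)c(C#N)c1N` gives a limit, > 5000 nM.
compound 2 `CC(C)Nc1sc(C(=O)c2ccco2)c(N)c1C#N` gives 1350 nM.
compound 3 `CC(C)Nc1sc(C(=O)c2ccc(Br)s2)c(N)c1C#N` gives 122 nM.

For the measured compounds named here, compound 3 has the lowest of the two numbers known; the nearest is compound 2, with an 11-fold lower number from compound 2 to compound 3 (1.04 log units; beyond the scatter). Compound 1 sits at the limit of > 5000 nM in this assay, at which 1 of the 3 values shown sits, so only a limit is known for it.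

Compound 4 `CC(C)Nc1sc(C(=O)c2cc(Cl)cs2)c(N)c1C#N` differs from compound 3 by 4-chlorothiophen-2-yl in place of 5-bromothiophen-2-yl on a carbonyl carbon. Going by the values given here, the steps that bear on this are an 11-fold lower number from compound 2 to compound 3 (1.04 log units; beyond the scatter) and an at least 40-fold lower number from compound 1 to compound 3 (1.61 log units; beyond the scatter): both show that the group on the carbonyl carbon moves this assay strongly, but each swaps the ring type or replaces methyl. Compound 4 keeps the thiophene and changes only the halogen and its position, so a smaller step is expected, within or slightly beyond the scatter, direction uncertain: a 2.0-fold higher number from compound 3 to compound 4 (0.31 log units; beyond the scatter). Compound 4 is estimated at 250 nM, range 70 nM to 900 nM.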

Compound 4, half-maximal inhibitory concentration: 575 nM
Estimate against measurement, compound 4: 2.3-fold (0.36 log units) below; the measured number falls inside the stated range.
By their numbers in this assay, from the lowest: compound 3; then compound 4; then compound 2. At a limit, above all of these: compound 1.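

With the thiophene kept, moving from 5-bromothiophen-2-yl to 4-chlorothiophen-2-yl on the carbonyl carbon still shifts this assay beyond the scatter (a 4.7-fold higher number from compound 3 to compound 4 (0.67 log units; beyond the scatter)). The thiophene alone therefore does not set the level, though 4-chlorothiophen-2-yl keeps a modest edge over furan-2-yl (a 2.3-fold lower number from compound 2 to compound 4 (0.37 log units; beyond the scatter)). Against methyl, only a bound can be read (an at least 8.6-fold lower number from compound 1 to compound 4 (0.93 log units; beyond the scatter)), since compound 1 is a limit: the limit of > 5000 nM in this assay, at which 1 of the 4 values shown sits.

This step changes halogen and place together, so the two remain inseparable; a 5-chlorothiophen-2-yl group would part them. From the compounds shown here alone, how an amine on that ring would read also remains open.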